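The source may report more compounds than this note shows. Statements on the series, on what has been measured and on what is new or still open speak of the compounds shown alone.

Compound 1 `CC1(C)C=C(n2ccccc2=O)c2cc(S(N)(=O)=O)ccc2O1` gives the lowest of the three numbers in a functional assay with Rattus norvegicus as the target (a higher number here means that more compound is needed for the effect, a lower number that less compound is needed), namely 69.2 nM. Its nearest neighbour is compound 3 `CC1(C)C=C(n2ccccc2=O)c2cc(S(=O)(=O)N3CCOCC3)ccc2O1` with 85.1 nM, a step of a 1.2-fold higher number from compound 1 to compound 3 (0.09 log units; within the scatter); the furthest is compound 2 `CC1(C)C=C(n2ccccc2=O)c2cc(S(=O)(=O)Nc3ccc([N+](=O)[O-])cc3)ccc2O1` with 2090 nM, a step of a 30-fold higher number from compound 1 to compound 2 (1.48 log units; beyond the scatter). Compound 4 `CC1(C)C=C(n2ccccc2=O)c2cc(S(=O)(=O)c3ccccc3)ccc2O1` differs from compound 1 by phenyl in place of amino on a sulfonyl sulfur. For the measured compounds named here, two measured steps bear on this: the large rise from compound 1 to compound 2, where an aromatic ring enters on the sulfonamide nitrogen, and the flat step from compound 1 to compound 3, where a saturated ring replaces the amino group on the sulfur. For compound 4 a moderate rise in this assay of about a 3.6-fold higher number from compound 1 to compound 4 (0.56 log units; beyond the scatter) is therefore expected, putting the estimated value near 250 nM, within 60 nM to 1500 nM.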

Compound 4, half-maximal effective concentration: 17.4 nM
The estimate for compound 4 lay 14-fold (1.16 log units) above the measured number, outside the stated range (below it).
By their numbers in this assay, from the lowest: compound 4; then compounds 1 and 3 (each within the scatter of the next); then compound 2.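

On the sulfonyl sulfur, phenyl gives a lower number than either amino (a 4.0-fold lower number from compound 1 to compound 4 (0.60 log units; beyond the scatter)) or morpholin-4-yl (a 4.9-fold lower number from compound 3 to compound 4 (0.69 log units; beyond the scatter)), and far lower than (4-nitrophenyl)amino (a 120-fold lower number from compound 2 to compound 4 (2.08 log units; beyond the scatter)). An aromatic ring at this place therefore does not in itself raise the number in this assay, and no sulfonamide nitrogen is needed for a low one. Nothing shown here accounts for these differences. From the compounds shown here alone, it remains open whether a benzyl group or a pyridine ring on the sulfur would match phenyl, and whether compound 2 owes its high number to the nitro group or to the nitrogen link.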